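Changing the sulfonyl group of compound 2

A few compounds are considered here, and "the series" means these few. Any claim that something is new, unique, unknown or untested is made for them only; others in the source may bear on it.

In a functional assay on A549 cells (Homo sapiens) for antiproliferative activity, read by MTT assay, with a stated time of 24 h (a higher number here means a weaker inhibitor, a lower number a stronger inhibitor), compound 1 `Cc1ccc(-c2nn(-c3ccccc3)cc2-c2nc3ccccc3n2S(=O)(=O)c2ccc(F)cc2)cc1` gives 3240 nM while compound 2 `Cc1ccc(C)c(S(=O)(=O)n2c(-c3cn(-c4ccccc4)nc3-c3ccc(C(F)(F)F)cc3)nc3ccccc32)c1` gives 150 nM as the lower of the two numbers. The gap between them lies well beyond the usual scatter of repeat measurements, so compound 2 is the stronger inhibitor of this pair.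

The next compound makes one change to compound 2. In compound 3 `O=S(=O)(c1ccc(F)cc1)n1c(-c2cn(-c3ccccc3)nc2-c2ccc(C(F)(F)F)cc2)nc2ccccc21` the change (4-fluorophenyl in place of 2,5-dimethylphenyl on a sulfonyl sulfur) puts 4-fluorophenyl in place of 2,5-dimethylphenyl on a sulfonyl sulfur. Among the compounds with values here, no pair of measured compounds shows this change alone, so its size can only be judged indirectly. Compound 1, with 3240 nM as its value, also carries 4-fluorophenyl on a sulfonyl sulfur. However, it differs from compound 3 elsewhere as well, so only part of its gap to compound 2 is expected to carry over. The expected step of a 4.7-fold higher number from compound 2 to compound 3 (0.67 log units; beyond the scatter) is a moderate one toward a weaker inhibitor, probably beyond the scatter. For compound 3 the estimated value is 700 nM with a likely range from 160 nM to 3000 nM as its span.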

Compound 3, half-maximal inhibitory concentration: 1740 nM
For compound 3 the middle estimate is 2.5-fold (0.40 log units) below the measured one; the measured number falls inside the stated range.
By their numbers in this assay, from the lowest: compound 2; then compounds 3 and 1 (each within the scatter of the next).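

In this assay, the sulfonyl sulfur now has a directly measured change: 4-fluorophenyl in place of 2,5-dimethylphenyl gives a 12-fold higher number from compound 2 to compound 3 (1.06 log units; beyond the scatter), so the group on this sulfur strongly affects the read-out when the rest of the molecule stays the same. The second comparison concerns a different place, where trifluoromethyl in place of methyl on an aromatic carbon gives a 1.9-fold lower number from compound 1 to compound 3 (0.27 log units; within the scatter), so with 4-fluorophenyl on the sulfonyl sulfur, this swap produces no difference that can be told from the scatter. No measurement shown explains why either change has the size it does.

As far as these compounds go, it remains open whether 2,5-dimethylphenyl owes its lower number to one methyl group, to both, or to the absence of the fluorine, and a plain phenyl or a 4-methoxyphenyl on the sulfonyl sulfur would help to separate these possibilities. It is also unknown whether trifluoromethyl and methyl would remain indistinguishable with 2,5-dimethylphenyl on the sulfur, since the compounds shown test that swap only with 4-fluorophenyl there.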